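This account rests on a few compounds, and the source may have more. Where it says the series, first, only, none or still open, it means among the compounds named here.

In an ADME assay on L929 cells (Mus musculus) for cytotoxicity, read by resazurin assay, with a stated time of 72 h (on this read-out lower numbers stand for stronger inhibition and higher numbers for weaker inhibition), compound 1 (`COCOc1cccc(C(=O)/C=C/c2ccc3c(c2)B(O)OC3)c1`) gives only a limit, > 10 ug/mL, and no number. Compound 2 (`CCc1ccc(C(=O)/C=C/c2ccc3c(c2)B(O)OC3)cc1`) also gives only a limit, > 10 ug/mL. Compound 3 (`COc1cccc(C(=O)/C=C/c2ccccc2)c1`) lacks the core of compound 1. Compound 3 gives a measured number, 5.7 ug/mL. Compound 4 (`COc1cccc(C(=O)/C=C/c2ccc3c(c2)B(O)OC3)c1`) keeps the core of compound 1 and has hydrogen in place of methoxy on a saturated chain carbon bound to an oxygen on an aromatic ring, so methoxymethoxy becomes methoxy (hydrogen in place of methoxy on a saturated chain carbon bound to an oxygen on an aromatic ring). Among the compounds with values here, no measured step shows what this change does in this assay. Expected here is a step that the limit leaves unreadable from compound 1 to compound 4, no more than the usual scatter and in no favoured direction. For compound 4 the estimated value is 12 ug/mL, with an expected range from 5 ug/mL to 30 ug/mL.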

Compound 4, half-maximal inhibitory concentration: > 10 ug/mL
Compound 4: no number, only a limit (the forecaster's own chance of this, stated with the estimate: 60%); the middle value is on the limit's open side.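

In this assay, within the data shown here, compound 1 and compound 4 both give only a limit, so no step between these two compounds can be read. The compounds shown leave open what the change from methoxymethoxy to methoxy does in this assay.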